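The source may report more compounds than this note shows. Statements on the series, on what has been measured and on what is new or still open speak of the compounds shown alone.

In an ADME assay on HeLa cells (Homo sapiens) for cytotoxicity, read by crystal violet staining, with a stated time of 72 h (a higher number here means that more compound is tolerated, a lower number that less compound is tolerated), three related compounds have been measured so far. Compound 3 `CN(C)C(=O)c1cc(CCCOc2ccc(-c3noc(C(F)(F)F)n3)cc2[N+](=O)[O-])on1` gives 22500 nM, and compound 2 `CN(C)C(=O)c1cc(CCCOc2ccc(-c3noc(C(F)(F)F)n3)cc2)on1` gives 28000 nM, the same within the scatter. Compound 1 `CCOC(=O)c1cc(CCCOc2ccc(-c3noc(C(F)(F)F)n3)cc2F)on1` gives a higher number, 60200 nM.

The next molecule, compound 4 `CN(C)C(=O)c1cc(CCCOc2ccc(-c3noc(C(F)(F)F)n3)cc2F)on1`, changes a single group of compound 3: fluoro in place of nitro on an aromatic carbon. Fluoro takes the place of nitro on an aromatic carbon, ortho to a large group and meta to a 5-(trifluoromethyl)-1,2,4-oxadiazol-3-yl group.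

Going by the values given here, the one measured step at this carbon is a 1.2-fold lower number from compound 2 to compound 3 (0.09 log units; within the scatter), with nitro in place of hydrogen. Compound 1 also carries the fluoro but differs from compound 4 elsewhere, so it offers only a loose guide. Among the compounds with values here, no measured step shows what fluoro does on this exact scaffold. Within the data shown here, with the only relevant step inside the scatter, no step beyond the scatter is expected in this assay. The estimated step is a 1.3-fold higher number from compound 3 to compound 4 (0.12 log units; within the scatter). Compound 4 is expected to give about 30000 nM, with an estimated range of 15000 nM to 60000 nM.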

Compound 4, half-maximal cytotoxic concentration: 20200 nM
The estimate for compound 4 lay 1.5-fold (0.17 log units) above the measured number, and the stated range covers the measured number.
By their numbers in this assay, from the lowest: compounds 4, 3 and 2 (each within the scatter of the next); then compound 1.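

On this aromatic carbon, hydrogen, nitro and fluoro cannot be told apart in this assay: replacing nitro with fluoro gives a 1.1-fold lower number from compound 3 to compound 4 (0.05 log units; within the scatter), and fluoro in place of hydrogen gives a 1.4-fold lower number from compound 2 to compound 4 (0.14 log units; within the scatter), both within the scatter. Going by these compounds alone, the one step beyond the scatter lies elsewhere in the compound: with fluoro kept on the aromatic carbon, dimethylamino in place of ethoxy on the carbonyl carbon gives a 3.0-fold lower number from compound 1 to compound 4 (0.47 log units; beyond the scatter), a modest step. No measured property of these compounds is available to explain either result.

As far as these compounds go, it remains open whether an amine or a carboxylic acid on this aromatic carbon would also stay within the scatter. Within the data shown here, the ethoxy to dimethylamino step is also seen only with fluoro on the ring, so it may not hold with hydrogen or nitro there.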